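The compounds below may be only part of what the source reports. "The series", "measured", "known", "first", "only" and "open" are said of these compounds alone.

Two compounds give the starting picture. Compound 1 `O=C1CS/C(=N\c2csc(-c3ccccc3)c2)N1` carries the shared core with nothing attached to its exocyclic carbon. In a functional assay on HCT-116 cells (Homo sapiens) for cytotoxicity, read by MTT assay, with a stated time of 72 h (on this read-out lower numbers stand for stronger inhibition and higher numbers for weaker inhibition), compound 1 reaches only a limit of the assay, > 50000 nM, not a number. Going by the values given here, compound 2 `CN(C)c1ccc(/C=C2\S/C(=N\c3csc(-c4ccc(Cl)cc4)c3)NC2=O)cc1` is the one measured value here: in this assay compound 2 gives 500 nM, so it stands alone as the single real number among the two values shown, and any comparison between measured compounds is absent.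

Compound 3 `O=C1N/C(=N/c2csc(-c3ccc(Cl)cc3)c2)S/C1=C\c1ccc(F)cc1` differs from compound 2 in one place: fluoro in place of dimethylamino on an aromatic carbon. Among the compounds with values here, no measured pair isolates this change, so the expectation rests on the structures alone. The step is estimated at a 3.0-fold higher number from compound 2 to compound 3 (0.48 log units; beyond the scatter), a weakening that goes beyond the usual scatter. Compound 3 is accordingly expected to give about 1500 nM, with a plausible range from 300 nM to 8000 nM.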

Compound 3, half-maximal inhibitory concentration: 7400 nM
Estimate against measurement, compound 3: 4.9-fold (0.69 log units) below, and the stated range covers the measured number.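

Going by these compounds alone, this is the first comparison between two real numbers: in this assay, going from 4-(dimethylamino)phenyl to 4-fluorophenyl gives a 15-fold higher number from compound 2 to compound 3 (1.17 log units; beyond the scatter) and so counts as a large weakening. The para position of this ring, the only place where the two compounds differ, is therefore not indifferent to what it carries, since exchanging dimethylamino for fluoro alone moves the cytotoxicity well past ordinary measurement noise. Nothing measured here says which feature of the two groups accounts for the loss.

On these data alone, with only these two groups to compare at this position, it remains open whether a plain amine, a methoxy group or a morpholine ring would stay close to compound 2 or fall towards compound 3. As far as these compounds go, it is also open whether a carboxylic acid there would weaken the number further.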